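The source may report more compounds than this note shows. Statements on the series, on what has been measured and on what is new or still open speak of the compounds shown alone.

In an in vitro functional assay on HEK ts201 cells for antagonist activity at Neuronal acetylcholine receptor; alpha4/beta2 (Homo sapiens), read by fluorescence and calcium flux (a higher number here means a weaker inhibitor, a lower number a stronger inhibitor), the three measured compounds stand as follows:

compound 1 `O=C(OCC1=CCCN(CCCc2ccccc2)C1)c1ccccc1N1C(=O)CC(Cc2ccccc2)C1=O`: 5130 nM
compound 2 `CC1CC(=O)N(c2ccccc2C(=O)OCC2CCCN(CCCCOc3ccc(Cl)c(Cl)c3)C2)C1=O`: 12300 nM
compound 3 `O=C(Nc1ccccc1)c1ccccc1-c1ccccc1`: 6900 nM

Compound 2 gives the highest of the three numbers in this assay. Compound 3 lies within the scatter of it, whereas compound 1 lies beyond the scatter on the lower side. Compound 4 `COc1cccc(OCCCCCN2CCCC(COC(=O)c3ccccc3N3C(=O)CC(C)C3=O)C2)c1OC` carries (2,3-dimethoxyphenoxy)methyl in place of 3,4-dichlorophenoxy on a saturated chain carbon, four bonds along the chain from an amine nitrogen in a ring relative to compound 2. Among the measured compounds shown here, no measured pair isolates this change, so nothing here fixes its direction; a step of modest size, either way, or none beyond the scatter, is what one would expect. The expected step is a 1.2-fold lower number from compound 2 to compound 4 (0.09 log units; within the scatter). Compound 4 is therefore estimated to give 10000 nM in this assay, with a range from 3000 nM to 35000 nM.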

Compound 4, half-maximal inhibitory concentration: 8710 nM
For compound 4 the middle estimate is 1.1-fold (0.06 log units) above the measured one; low and high end bracket the measured number.
By their numbers in this assay, from the lowest: compounds 1, 3, 4 and 2 (each within the scatter of the next, the first and the last beyond it).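

Among the compounds shown here, the step in this assay (a 1.4-fold lower number from compound 2 to compound 4 (0.15 log units; within the scatter)) gives the first reading of a single change at this place, on a saturated chain carbon, four bonds along the chain from an amine nitrogen in a ring. Replacing 3,4-dichlorophenoxy with the larger (2,3-dimethoxyphenoxy)methyl, which has no chlorine and more oxygen, moves the number no further than the scatter. Nothing available explains this outcome.

As far as these compounds go, whether an amine or a carboxylic acid at this place would also leave the number within the scatter remains open.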